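Ethyl ester of compound 1 in a cell assay

The source may report more compounds than this note shows. Statements on the series, on what has been measured and on what is new or still open speak of the compounds shown alone.

Compound 1 `COc1cc(-c2nc3ccccc3s2)ccc1OCC(=O)NNC(=O)CNC(=N)NCCC[C@H](N[N+](=O)[O-])C(=O)O` – 3490 nM
Compound 2 `CCOC(=O)[C@H](CS(=O)(=O)O)NCC(=O)NNC(=O)COc1ccc(-c2nc3ccccc3s2)cc1OC` – 3360 nM

In a functional assay on HepG2 cells (Homo sapiens) for inhibition, read by MTT assay, with a stated time of 3 days (a lower number here means a stronger inhibitor, a higher number a weaker inhibitor), compound 1 gives 3490 nM and stands level with compound 2, as the two values lie within the scatter of each other. Compound 3 `CCOC(=O)[C@H](CCCNC(=N)NCC(=O)NNC(=O)COc1ccc(-c2nc3ccccc3s2)cc1OC)N[N+](=O)[O-]` differs from compound 1 by ethyl in place of hydrogen on an oxygen next to a carbonyl group and so turns carboxy to ethoxycarbonyl. Within the data shown here, no measured pair shows this change alone. Compound 2 also carries ethoxycarbonyl and gives 3360 nM on the same core, so no step beyond the scatter is expected in this assay here. The expected 1.2-fold lower number from compound 1 to compound 3 (0.07 log units; within the scatter) is therefore small. The estimate for compound 3 is 3000 nM with an expected range from 1200 nM to 7000 nM.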

Compound 3, half-maximal inhibitory concentration: 3730 nM
The estimate for compound 3 lay 1.2-fold (0.09 log units) below the measured number; measured number inside the range.
By their numbers in this assay, from the lowest: compounds 2, 1 and 3 (each within the scatter of the next).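

In this assay, the step from free acid to ester can now be read directly: ethyl in place of hydrogen on an oxygen next to a carbonyl group gives a 1.1-fold higher number from compound 1 to compound 3 (0.03 log units; within the scatter) and leaves the two compounds level. On this core, carboxy and ethoxycarbonyl therefore cannot be told apart in this read-out. No data on any property of these compounds bear on this result. Going by these compounds, whether a primary amide or a butyl ester at this place would also stand level with compound 1 remains open. So does whether the carboxylic acid matching compound 2 would stand level with compound 2.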